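From Hydroxy to Methoxy on Compound 3

The source may report more compounds than this note shows. Statements on the series, on what has been measured and on what is new or still open speak of the compounds shown alone.

Of the compounds shown here, three on a shared core have been read in an ADME assay on HepG2 cells (Homo sapiens) for cytotoxicity, read by resazurin assay, with a stated time of 24 h; on this read-out lower numbers stand for higher toxicity in this test and higher numbers for lower toxicity in this test. Compound 1 `O=C(O)c1c(O)cccc1CCc1ccc2ccccc2c1` gives > 100000 nM, which is a limit and not a number. Compound 3 `CCN(CC)C(=O)c1c(O)cccc1CCc1ccc2ccccc2c1` gives > 100000 nM, which is also a limit. Among the compounds with values here, compound 2 `CCN(CC)C(=O)c1c(CCc2ccc3ccccc3c2)cc(OC)cc1OC` gives 59000 nM, the only true number of the three. Compound 3 therefore stands at the limit of > 100000 nM in this assay, at which 2 of the 3 values shown sit.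

Compound 4 `CCN(CC)C(=O)c1c(CCc2ccc3ccccc3c2)cccc1OC` comes from compound 3 by one change, hydroxy to methoxy: methyl in place of hydrogen on an oxygen on an aromatic ring. Within the data shown here, the only measured step, a step that the two limits leave unreadable from compound 1 to compound 3, lies on a carbonyl carbon and gives no size for this change. The nearest guide is compound 2, which has no hydroxy, carries methoxy and differs further, at 59000 nM. A modest move towards higher toxicity is therefore expected, though the reading may well remain a limit. In this assay the estimated step is an at least 1.2-fold lower number from compound 3 to compound 4 (0.09 log units; that floor lies within the scatter). For compound 4 the estimated value is 80000 nM, with an expected range of 40000 nM to 140000 nM.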

Compound 4, half-maximal cytotoxic concentration: 35800 nM
Compound 4: middle estimate off by 2.2-fold (0.35 log units), on the high side; the whole stated range lies above it.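

In this assay, hydroxy to methoxy gives the first readable move at this oxygen on an aromatic ring: an at least 2.7-fold lower number from compound 3 to compound 4 (0.44 log units; beyond the scatter). That size is only a floor, since compound 3 is read as a limit and not a number: the limit of > 100000 nM in this assay, at which 2 of the 4 values shown sit A second comparison shows that hydrogen in place of methoxy on an aromatic carbon gives no difference that can be told from the scatter: a 1.6-fold lower number from compound 2 to compound 4 (0.22 log units; within the scatter).

From the compounds shown here alone, whether a longer chain on the same oxygen, such as ethoxy or propoxy, would carry the number further down stays open, and so does the true size of the step from hydroxy to methoxy. Also open, going by these compounds, is whether the carboxylic acid of compound 1, with methoxy in place of its hydroxy, would show a step of the same kind.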